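The compounds below may be only part of what the source reports. "The series", "measured", "known", "first", "only" and "open" are said of these compounds alone.

Compound 1 `COc1ccccc1N1C(=O)CSC1c1cccc(C(=O)NCCCCc2ccc(Cl)cc2)c1`: 78.6 nM
Compound 2 `O=C(NCCCCc1ccccc1)c1cccc(C2SCC(=O)N2c2ccc(C3CC3)cc2)c1`: 217 nM

In a functional assay on HOS-TE85 cells (Homo sapiens) for inhibition, read by CCK-8 assay, with a stated time of 72 h (on this read-out lower numbers stand for stronger inhibition and higher numbers for weaker inhibition), compound 1 gives 78.6 nM, the lower of the two numbers and clearly apart from compound 2 at 217 nM. Compound 3 `COc1ccccc1N1C(=O)CSC1c1cccc(C(=O)NCCCCn2ccc3ccccc32)c1` keeps the rest of compound 1 but has 1H-indol-1-yl in place of 4-chlorophenyl on a saturated chain carbon, four bonds along the chain from an amide-type nitrogen. Among the measured compounds shown here, no measured pair shows this kind of change, so the forecast is uncertain. A small move towards weaker inhibition is expected, estimated as a 1.5-fold higher number from compound 1 to compound 3 (0.18 log units; within the scatter). For compound 3, the estimated value is 120 nM, with an expected range of 40 nM to 400 nM.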

Compound 3, half-maximal inhibitory concentration: 286 nM
The estimate for compound 3 lay 2.4-fold (0.38 log units) below the measured number; the measured number falls inside the stated range.
By their numbers in this assay, from the lowest: compound 1; then compounds 2 and 3 (each within the scatter of the next).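

In this assay, 1H-indol-1-yl in place of 4-chlorophenyl gives a 3.6-fold higher number from compound 1 to compound 3 (0.56 log units; beyond the scatter) and so weakens inhibition. This is the first single-place change shown, and it establishes that the group at the end of the chain matters: compound 1 and compound 2 differ in more than one place, so they could not show this. No measurement here explains why the number rises. Going by these compounds, it remains open how a 4-fluorophenyl or a morpholine at the same chain end would compare. On these data alone, the effect of a longer chain carrying the 4-chlorophenyl also remains open.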